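The source may hold more compounds than are shown below. What is called first, only, known or untested is meant among the compounds shown, and "the series" means these compounds.

Measured so far:
- compound 1 `CC(C)c1ccc(OC(C)(Cc2ccc(Cl)cc2)C(=O)NS(C)(=O)=O)cc1` with 5 mg/kg in a functional assay on the whole organism for inhibition, with Rattus norvegicus as the target; a higher number here means that more compound is needed for the effect, a lower number that less compound is needed
- compound 2 `CC(C)c1ccc(OC(C)(Cc2ccc(Cl)cc2)C(=O)/N=C(\N)NO)cc1` with 10 mg/kg in this assay

For the measured compounds named here, compound 2 stands level with compound 1 on these numbers: the only measured step is a 2.0-fold higher number from compound 1 to compound 2 (0.30 log units; within the scatter) and it lies within the usual scatter.

Compound 3 `CC(C)c1ccc(OC(C)(Cc2ccc(Cl)cc2)C(=O)CO)cc1` keeps the shared core and differs from compound 2 in one place, on a carbonyl carbon whose other neighbours are a saturated chain carbon. The difference is a group of 2 heavy atoms (1 carbon, 1 oxygen; no ring) in place of a group of 5 heavy atoms (1 carbon, 3 nitrogen, 1 oxygen; no ring), on a carbonyl carbon with hydroxymethyl as the entering group.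

Going by the values given here, the one measured step bears on this change, as it also exchanged one group on a carbonyl carbon for another, and the two numbers stayed within the scatter. Hydroxymethyl itself has no measurement on this core, so this is thin evidence, and no step beyond the scatter is the cautious expectation. The expected change is a 1.2-fold higher number from compound 2 to compound 3 (0.08 log units; within the scatter) and so is no real shift in this assay as far as can be foreseen. Compound 3 is expected at 12 mg/kg, within an estimated range from 3 mg/kg to 50 mg/kg, kept wide on purpose.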

Compound 3, dose for half-maximal effect: > 10 mg/kg
Compound 3 gave a limit, no number (the forecaster's own chance of this, stated with the estimate: 15%); the middle value does not contradict the limit.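

For compound 3, which has hydroxymethyl on the carbonyl carbon and so is the first of these compounds with a group there containing no nitrogen, the result in this assay is a limit and not a number, and the step is a number no lower from compound 2 to compound 3 (the limit leaves the size open): the limit of > 10 mg/kg in this assay, at which 1 of the 3 values shown sits. Compared with the methanesulfonamido group of the earlier compound, this change gives an at least 2.0-fold higher number from compound 1 to compound 3 (0.30 log units; that floor lies within the scatter), so even the smallest step it allows cannot be told apart from ordinary variation between repeated measurements, while the true step may be larger. The step from the hydroxyguanidine-like group of compound 2 cannot be read, since the limit leaves its size open, so this position has not yet been shown to tolerate or to reject a group as small as hydroxymethyl.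

Going by these compounds, what stays open is the actual dose that compound 3 needs, and therefore whether removing the nitrogen-containing group makes any real difference in this assay. Also open, on these data alone, is how a carboxylic acid, a simple amine or a longer chain ending in hydroxyl would behave on the same carbonyl carbon.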